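Removing a Methyl from Compound 2's Methoxy Group

The compounds below may be only part of what the source reports. "The series", "measured", "known", "first", "only" and "open" are said of these compounds alone.

Within the data shown here, compound 2 `COc1ccc(NC(=O)[C@H]2CCCN2C(=O)C2(c3cccc(Cl)c3)CCCC2)cc1` gives 100 nM in an assay on isolated protein for inhibition of histone acetyltransferase p300 (Homo sapiens), with a stated time of 60 min (on this read-out higher numbers stand for weaker inhibition and lower numbers for stronger inhibition), the higher of the two numbers so far; compound 1 `O=C1Cc2cc(NC(=O)[C@H]3CCCN3C(=O)C3(c4cccc(Cl)c4)CCCC3)ccc2N1` gives 0.794 nM, and the step of a 130-fold higher number from compound 1 to compound 2 (2.10 log units; beyond the scatter) was large. Compound 3 `O=C(Nc1ccc(O)cc1)[C@H]1CCCN1C(=O)C1(c2cccc(Cl)c2)CCCC1` differs from compound 2 by hydrogen in place of methyl on an oxygen on an aromatic ring. Among the measured compounds shown here, no measured step changes this position, so the one known step offers little guidance. Compound 3 is expected to show a 2.5-fold lower number from compound 2 to compound 3 (0.40 log units; beyond the scatter), a modest move toward a lower number, with an estimate of 40 nM, ranging from 6 nM to 250 nM.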

Compound 3, half-maximal inhibitory concentration: 0.631 nM
The estimate for compound 3 lay 63-fold (1.80 log units) above the measured number; the measured number lies below the stated range.
By their numbers in this assay, from the lowest: compounds 3 and 1 (each within the scatter of the next); then compound 2.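

At this position, losing one methyl from the oxygen is enough to give a 160-fold lower number from compound 2 to compound 3 (2.20 log units; beyond the scatter) in this assay, so methoxy and hydroxy are far from interchangeable here. The step of a 1.3-fold lower number from compound 1 to compound 3 (0.10 log units; within the scatter) lies within the scatter, so the simple 4-hydroxyphenyl group does as well in this assay as the larger group on the amide-type nitrogen of compound 1. Nothing available explains the effect of the methyl. The compounds shown leave open how an amine, a carboxylic acid or a fluorine in place of the hydroxy group would compare.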